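Methyl for Trifluoromethyl on the Anilino Ring

This account rests on a few compounds, and the source may have more. Where it says the series, first, only, none or still open, it means among the compounds named here.

Compound 2 `FC(F)(F)c1ccc(CSc2nc(Nc3ccccc3C(F)(F)F)c3ccccc3n2)cc1` gives 34800 nM in a functional assay on PC-3 cells (Homo sapiens) for cytotoxicity, read by MTT assay, with a stated time of 72 h (a higher number here means a weaker inhibitor, a lower number a stronger inhibitor), the higher of the two numbers at hand, while compound 1 `CCCCCCCCNc1nc(SCc2ccc(C(F)(F)F)cc2)nc2ccccc12` gives 10500 nM. Within the data shown here, the single measured step, a 3.3-fold higher number from compound 1 to compound 2 (0.52 log units; beyond the scatter), swaps octyl for 2-(trifluoromethyl)phenyl on the nitrogen and does not touch the substituent in question. Compound 3 `Cc1ccccc1Nc1nc(SCc2ccc(C(F)(F)F)cc2)nc2ccccc12` differs from compound 2 by methyl in place of trifluoromethyl on an aromatic carbon, on an aromatic carbon ortho to a large group. Among the measured compounds shown here, no measured step bears on this change, so the expected step is a 1.2-fold lower number from compound 2 to compound 3 (0.06 log units; within the scatter), nothing beyond the scatter. Compound 3 is therefore estimated at 30000 nM, within 12000 nM to 80000 nM.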

Compound 3, half-maximal inhibitory concentration: 36900 nM
For compound 3 the middle estimate is 1.2-fold (0.09 log units) below the measured one; measured number inside the range.
By their numbers in this assay, from the lowest: compound 1; then compounds 2 and 3 (each within the scatter of the next).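

In this assay, the change shows that methyl can stand in for trifluoromethyl on this aromatic carbon with a 1.1-fold higher number from compound 2 to compound 3 (0.03 log units; within the scatter) and no reading of a real difference. The octyl comparison also holds with the new group, with a 3.5-fold higher number from compound 1 to compound 3 (0.55 log units; beyond the scatter) as the printed step, again beyond the scatter. Nothing at hand accounts for how little the swap on this carbon matters. As far as these compounds go, whether an amine, a methoxy group or a plain hydrogen on this carbon would give a similar number remains open.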